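A few compounds are considered here, and "the series" means these few. Any claim that something is new, unique, unknown or untested is made for them only; others in the source may bear on it.

In an ADME assay on Vero cells (Chlorocebus sabaeus) for cytotoxicity, read by CellTiter-Glo, with a stated time of 72 h (a higher number here means that more compound is tolerated, a lower number that less compound is tolerated), the measured compounds are

- Compound 1 `[O-][n+]1nc(NC2CCC2)[n+]([O-])c2ccccc21` gives 8.9 ug/mL
- Compound 2 `[O-][n+]1nc(NC2CCC2)[n+]([O-])c2ccc(Br)cc21` gives 3.8 ug/mL
- Compound 3 `CCNc1n[n+]([O-])c2cc(C)c(OC)cc2[n+]1[O-]` gives > 100 ug/mL

Compound 3 stands at the limit of > 100 ug/mL in this assay, at which 1 of the 3 values shown sits, so its entry is a limit and not a number.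

Compound 4 `COc1cc2c(cc1C)[n+]([O-])nc(N[C@@H]1C[C@H]3CC[C@@H]1C3)[n+]2[O-]` differs from compound 3 in one place: a group of 7 heavy atoms (7 carbon; 2 five-membered non-aromatic rings of carbon only) in place of a group of 2 heavy atoms (2 carbon; no ring), on a nitrogen on an aromatic ring.

For the measured compounds named here, the only measured step, a 2.3-fold lower number from compound 1 to compound 2 (0.37 log units; beyond the scatter), concerns a bromo and not this group, so it gives only a rough sense of size. A closer hint comes from compound 1, which has a ring-bearing group on that nitrogen and gives 8.9 ug/mL, although its core differs from that of compound 3. A large move to a lower number is therefore expected, with much uncertainty: an at least 6.6-fold lower number from compound 3 to compound 4 (0.82 log units; beyond the scatter). Compound 4 is estimated at 15 ug/mL, with an expected range of 4 ug/mL to 70 ug/mL.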

Compound 4, half-maximal cytotoxic concentration: > 50 ug/mL
Compound 4: a limit, no number (the forecaster's own chance of this, stated with the estimate: 15%); middle value at least 3.3-fold (0.52 log units) from the limit.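

No step can be read between compound 3 and compound 4 in this assay: each gives a limit and not a number. The compounds shown leave open whether replacing ethyl with the group of 7 heavy atoms changes the tolerated concentration at all.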